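Phenyl added to a benzyl ether in Vero cell cytotoxicity

The source may report more compounds than this note shows. Statements on the series, on what has been measured and on what is new or still open speak of the compounds shown alone.

Compound 1 `CN1Cc2ccc(OCCCN3CCNCC3)cc2[C@@H](O)C1` — in an ADME assay on Vero cells (Chlorocebus sabaeus) for cytotoxicity, read by sulforhodamine B assay, with a stated time of 72 h (on this read-out higher numbers stand for weaker inhibition and lower numbers for stronger inhibition), compound 1 reports > 100000 nM, which is a limit of the assay and not a number.
Compound 2 `CN1Cc2ccc(OCc3ccc(-c4cccc(Cl)c4)cc3)cc2[C@@H](O)C1` — in this assay compound 2 gives 25500 nM.
Compound 3 `OC1CCCc2ccc(OCc3ccccc3)cc21` — in this assay compound 3 gives 39000 nM.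

Compound 3 holds the highest of the two numbers, and the value of compound 2 sits close to it, within the scatter. Compound 4 `OC1CCCc2ccc(OCc3ccc(-c4ccccc4)cc3)cc21` differs from compound 3 by phenyl in place of hydrogen on an aromatic carbon. Going by the values given here, no step between two measured compounds is available for this change. Compound 2, which carries a second aromatic ring on its benzyl ether and gives 25500 nM, sits within the scatter of compound 3, so no step beyond the scatter is expected in this assay. Compound 4 is estimated at 30000 nM, between 12000 nM and 75000 nM. The expected step from compound 3 to compound 4 is a 1.3-fold lower number from compound 3 to compound 4 (0.11 log units; within the scatter).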

Compound 4, half-maximal inhibitory concentration: > 100000 nM
Compound 4 ended at the assay's limit; the forecaster's own chance of this, stated with the estimate: 10%; at least 3.3-fold (0.52 log units) between middle value and limit.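

Phenyl in place of hydrogen on an aromatic carbon, para to a large group, gives an at least 2.5-fold higher number from compound 3 to compound 4 (0.40 log units; beyond the scatter) in this assay, so at this position the added ring goes with weaker inhibition. The value of compound 4 is a limit of the assay, so the step fixes only the smallest possible size of the change: the limit of > 100000 nM in this assay, at which 2 of the 4 values shown sit.

Going by these compounds, how far the true value of compound 4 lies past that limit stays open. The compounds shown also leave open whether a methyl group, a chlorine atom or a phenyl ring carrying an amine at this place would raise the number too.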